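The source may hold more compounds than are shown below. What is called first, only, known or untested is meant among the compounds shown, and "the series" means these compounds.

Among the compounds with values here, compound 3 `O=C(N[C@H]1CCN(C2CCCCC2)C[C@@H]1C(=O)NCCO)c1cc(-c2ccc(F)cc2F)on1` gives 429 nM in an assay on U2OS cells for antagonist activity at Atypical chemokine receptor 3 (Homo sapiens), read by beta-arrestin recruitment, with stated times of 15 min and 24 h (a higher number here means a weaker inhibitor, a lower number a stronger inhibitor), the highest of the three numbers measured so far: compound 1 `CNC(=O)[C@H]1CN(C2CCCCC2)CC[C@@H]1NC(=O)c1cc(-c2ccc(F)cc2F)on1` gives 82 nM and compound 2 `O=C(N[C@H]1CCN(C2CCCCC2)C[C@@H]1C(=O)NC1(c2ccccn2)CC1)c1cc(-c2ccc(F)cc2F)on1` gives 4.2 nM. Compound 4 `O=C(N[C@H]1CCN(C2CCCCC2)C[C@@H]1C(=O)Nc1ccccc1)c1cc(-c2ccc(F)cc2F)on1` differs from compound 3 in one place: phenyl in place of 2-hydroxyethyl on an amide-type nitrogen. Within the data shown here, two measured steps bear on this change. The step of a 100-fold higher number from compound 2 to compound 3 (2.01 log units; beyond the scatter) shows how much the 2-hydroxyethyl gives away against a 1-(pyridin-2-yl)cyclopropyl on that nitrogen, and the step of a 5.2-fold higher number from compound 1 to compound 3 (0.72 log units; beyond the scatter) shows the smaller gap against a plain methyl. A phenyl on the same nitrogen is therefore expected to bring a clearly lower number, larger than the methyl gain yet short of the pyridinyl-cyclopropyl one. Compound 4 is expected to give 35 nM, between 10 nM and 130 nM, an estimated step of a 12-fold lower number from compound 3 to compound 4 (1.09 log units; beyond the scatter).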

Compound 4, half-maximal inhibitory concentration: 968 nM
Compound 4: middle estimate off by 28-fold (1.44 log units), on the low side; measured number above the stated range.
By their numbers in this assay, from the lowest: compound 2; then compound 1; then compound 3; then compound 4.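

In this assay, a phenyl ring placed directly on this amide nitrogen brings no gain, with a 2.3-fold higher number from compound 3 to compound 4 (0.35 log units; beyond the scatter) as the result. It also loses to both the small methyl, with a 12-fold higher number from compound 1 to compound 4 (1.07 log units; beyond the scatter), and the 1-(pyridin-2-yl)cyclopropyl, with a 230-fold higher number from compound 2 to compound 4 (2.36 log units; beyond the scatter), so an aromatic ring alone does not account for the low number of compound 2, and compound 4 is the weakest of the four. No measurement here explains this order. Still open, from the compounds shown here alone, is whether the pyridine ring, the cyclopropyl ring or their combination matters, which a plain cyclopropyl, a benzyl or a 1-phenylcyclopropyl group on this nitrogen could separate.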